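This account rests on a few compounds, and the source may have more. Where it says the series, first, only, none or still open, it means among the compounds named here.

Compound 1 `CCC(=O)N1C[C@@H](C(=O)N2CCN(c3ccc(C)cc3[C@@H](NC(=O)CCN(C)C)C(C)C)CC2)[C@H](c2ccc(Cl)cc2)C1`: 27 nM
Compound 2 `CC(=O)N1C[C@@H](C(=O)N2CCN(c3ccc(C)cc3[C@@H](NC(=O)CCN(C)C)C(C)C)CC2)[C@H](c2ccc(Cl)cc2)C1`: 44 nM

Both were tested in a functional assay on CHO cells for agonist activity at Melanocortin receptor 4 (Homo sapiens), read by cAMP accumulation; a lower number here means that less compound is needed, a higher number that more compound is needed for the effect. Compound 2 has only compound 1 beside it for comparison, and the step of a 1.6-fold higher number from compound 1 to compound 2 (0.21 log units; within the scatter) lies within the scatter. Compound 3 `Cc1ccc(N2CCN(C(=O)[C@@H]3CNC[C@H]3c3ccc(Cl)cc3)CC2)c([C@@H](NC(=O)CCN(C)C)C(C)C)c1` differs from compound 2 by hydrogen in place of acetyl on an amine nitrogen in a ring. For the measured compounds named here, that single measured step bears on this change, as it also shortened the chain on the same ring nitrogen without any shift beyond the scatter; removing the acetyl altogether, leaving a free ring amine, has no direct precedent here. The expected step is modest, a 1.6-fold higher number from compound 2 to compound 3 (0.20 log units; within the scatter). Compound 3 is estimated at 70 nM, between 15 nM and 350 nM.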

Compound 3, half-maximal effective concentration: 79 nM
For compound 3 the middle estimate is 1.1-fold (0.05 log units) below the measured one, and the stated range covers the measured number.
By their numbers in this assay, from the lowest: compounds 1, 2 and 3 (each within the scatter of the next, the first and the last beyond it).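

For the compounds shown here, for the first time, the amine nitrogen in the ring carries only hydrogen, with no acyl group left on it. Going by these compounds alone, replacing acetyl with hydrogen gives a 1.8-fold higher number from compound 2 to compound 3 (0.25 log units; within the scatter) and stays within the scatter, whereas replacing propanoyl with hydrogen gives a 2.9-fold higher number from compound 1 to compound 3 (0.47 log units; beyond the scatter) and is the first step here beyond it, though a modest one. Compound 3, with its free ring amine, therefore still acts as an agonist, and the clear need for more compound appears only against compound 1. From the compounds shown here alone, how a butanoyl group or a plain methyl on this nitrogen would compare remains open. No available evidence explains these steps.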